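Replacing the azetidin-1-yl group of compound 2

The compounds below may be only part of what the source reports. "The series", "measured", "known", "first", "only" and "open" are said of these compounds alone.

Compound 1 `O=C1C(Nc2ccccc2F)=CC(=O)c2c1nc1n2[C@H]2OC[C@@H](O)[C@H]2OC1`: 2660 nM
Compound 2 `O=C1C=C(N2CCC2)C(=O)c2c1nc1n2[C@H]2OC[C@@H](O)[C@H]2OC1`: > 16000 nM (a limit)
Compound 3 `CCc1ccc(NC2=CC(=O)c3c(nc4n3[C@H]3OC[C@@H](O)[C@H]3OC4)C2=O)cc1`: > 4000 nM (a limit)

These results come from a functional assay on ECa-109 cells for inhibition, with ECa-109 cell line (Homo sapiens) as the target, read by sulforhodamine B assay; on this read-out higher numbers stand for weaker inhibition and lower numbers for stronger inhibition. Compound 2 stands at > 16000 nM, which is a limit of the assay and not a number. Only compound 1 has a true number here.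

Compound 4 `CCc1ccc(NC2=CC(=O)c3nc4n(c3C2=O)[C@H]2OC[C@@H](O)[C@H]2OC4)cc1` is reached from compound 2 by one change, (4-ethylphenyl)amino in place of azetidin-1-yl on a double-bonded ring carbon.

For the measured compounds named here, one measured step bears on this indirectly: an at least 1.5-fold higher number from compound 1 to compound 3 (0.17 log units; that floor lies within the scatter). It exchanges one aromatic ring on an amine nitrogen for another, so it does not test the loss of azetidin-1-yl. Compound 3 carries the same (4-ethylphenyl)amino group as compound 4, although the two structures are not identical. Compound 3 gives > 4000 nM, which is also a limit.

Compound 1 gives 2660 nM, so a lower number in this assay is expected, though its size is uncertain. The expected change is an at least 2.6-fold lower number from compound 2 to compound 4 (0.42 log units; beyond the scatter). For compound 4, the estimated value is 6000 nM, within a range of 2000 nM to 16000 nM.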

Compound 4, half-maximal inhibitory concentration: 3080 nM
The estimate for compound 4 lay 1.9-fold (0.29 log units) above the measured number; the range from low to high includes it.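

In this assay, putting (4-ethylphenyl)amino in place of azetidin-1-yl on the double-bonded ring carbon gives an at least 5.1-fold lower number from compound 2 to compound 4 (0.71 log units; beyond the scatter). This is the first step shown that removes azetidin-1-yl, and it shows that the group at this place matters: the larger group, with its six-membered aromatic ring and amine hydrogen, gives a true number for compound 4. The full size of the step stays unknown because compound 2 sits at a limit: the limit of > 16000 nM in this assay, at which 1 of the 4 values shown sits.

The compounds shown leave open which part of the new group carries the gain, the aromatic ring or the amine hydrogen. A cyclohexylamino group at this place would keep the amine hydrogen without the aromatic ring, while a piperidin-1-yl group would have neither.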